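The source may hold more compounds than are shown below. What is called first, only, known or untested is meant among the compounds shown, and "the series" means these compounds.

Working notes on the series in an assay on mitochondria (strain BALB/c) for inhibition of glycerol-3-phosphate acyltransferase 1, mitochondrial (Mus musculus), read by scintillation counting, with a stated time of 10 min; a lower number here means a stronger inhibitor, a higher number a weaker inhibitor. Compound 1 `CCCCCCCCS(=O)(=O)Nc1ccc(-c2ccccc2OC)cc1C(=O)O` gives 27600 nM in this assay. Compound 2 `CCCCCCCCS(=O)(=O)Nc1ccc(-c2ccc(OC)cc2)cc1C(=O)O` gives 19500 nM in this assay. Compound 3 `CCCCCCCCS(=O)(=O)Nc1ccc(-c2cccc(F)c2)cc1C(=O)O` gives 37600 nM in this assay, the highest of the three numbers, though a 1.4-fold higher number from compound 1 to compound 3 (0.13 log units; within the scatter) and a 1.9-fold higher number from compound 2 to compound 3 (0.29 log units; within the scatter) both stay within the scatter, so no order among the three can be read from them. The step from 1 to 2 a 1.4-fold lower number from compound 1 to compound 2 (0.15 log units; within the scatter) is likewise within the scatter.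

Compound 4 `CCCCCCCCS(=O)(=O)Nc1ccc(CCc2ccccc2)cc1C(=O)O` follows from compound 3 by phenethyl in place of 3-fluorophenyl on an aromatic carbon. None of the three measured steps exchanges the aryl substituent for a two-carbon linker to a phenyl, so the bearing of each is indirect: all three swap one substituted phenyl for another and all three stay within the scatter. On that basis no step beyond the scatter is expected for a 1.3-fold lower number from compound 3 to compound 4 (0.10 log units; within the scatter) in this assay, the direction being open. The estimate for compound 4 in this assay is 30000 nM, with an expected range from 9000 nM to 100000 nM.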

Compound 4, half-maximal inhibitory concentration: 37500 nM
Compound 4: middle estimate off by 1.3-fold (0.10 log units), on the low side, within the range that was stated.
By their numbers in this assay, from the lowest: compounds 2, 1, 4 and 3 (each within the scatter of the next).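

Phenethyl on this aromatic carbon, para to a large group, holds its phenyl ring away from the core on a chain, unlike the directly attached rings of the earlier compounds, yet in this assay no step leaves the scatter (a 1.0-fold lower number from compound 3 to compound 4 (0.00 log units; within the scatter); a 1.9-fold higher number from compound 2 to compound 4 (0.28 log units; within the scatter); a 1.4-fold higher number from compound 1 to compound 4 (0.13 log units; within the scatter)). Across these four compounds, then, the change from a directly attached substituted phenyl to phenethyl gives no readable difference, in either direction, against any of the three. No available data bear on this result.

Still open, as far as these compounds go, is whether any group at this position can move the number beyond the scatter, since all four compounds carry a hydrophobic-free reading of nothing more than a phenyl-bearing group here. An aminomethyl group, a carboxylic acid or a longer phenylbutyl chain would test that.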